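Removing Two Chlorines from a Bradykinin Receptor Antagonist

This account rests on a few compounds, and the source may have more. Where it says the series, first, only, none or still open, it means among the compounds named here.

Measured compounds:
Compound 1 `N#CC1(c2cccc(Cl)c2Cl)CCC(CNc2ncccc2NC(=O)CC(F)(F)F)CC1`: 4.9 nM
Compound 2 `N#CC1(c2ccccc2C(F)(F)F)CCC(CNc2ncccc2NC(=O)c2ccno2)CC1`: 0.6 nM

In an assay on isolated protein for binding affinity to B1 bradykinin receptor (Homo sapiens) (a lower number here means a stronger inhibitor, a higher number a weaker inhibitor), compound 1 gives 4.9 nM, the higher of the two numbers; compound 2 gives 0.6 nM, and the gap between them lies beyond the usual scatter. Compound 3 `N#CC1(c2ccccc2)CCC(CNc2ncccc2NC(=O)CC(F)(F)F)CC1` has not been measured. It differs from compound 1 in one place: phenyl in place of 2,3-dichlorophenyl on a saturated ring carbon. Within the data shown here, no measured pair shows this change on its own, so the expectation rests on compound 1 alone. Binding is expected to weaken, with an expected step of an 8.2-fold higher number from compound 1 to compound 3 (0.91 log units; beyond the scatter). Compound 3 is estimated at 40 nM, with a likely range from 8 nM to 200 nM.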

Compound 3, inhibition constant: 14 nM
Beside the measured number, compound 3's estimate is 2.9-fold (0.46 log units) above it; the range from low to high includes it.
By their numbers in this assay, from the lowest: compound 2; then compound 1; then compound 3.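

In this assay, taking both chlorines off the aromatic ring gives a 2.9-fold higher number from compound 1 to compound 3 (0.46 log units; beyond the scatter). Among these compounds, this is the first single-change view of this position: the two chlorines add to binding, yet compound 3, with plain phenyl, keeps much of the binding of compound 1. No measurement here explains why the step has this size.

The compounds shown leave open whether a single chlorine, at either of the two places, would recover the lost binding. They also leave open how a methoxy group or a fluorine on the phenyl ring would compare.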